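The compounds below may be only part of what the source reports. "The series", "measured", "known", "first", "only" and "open" are said of these compounds alone.

Of the compounds shown here, three sharing one core have been tested in an assay on microsomes from liver for inhibition of acyl-CoA desaturase 1 (Rattus norvegicus); a higher number here means a weaker inhibitor, a lower number a stronger inhibitor. Compound 1 `Cc1ccc(OC2CCN(c3ccc(-n4ccnc4)nn3)CC2)cc1` gives 527 nM in this assay. Compound 2 `Cc1cccc(OC2CCN(c3ccc(-n4ccnc4)nn3)CC2)c1` differs from compound 1 only in its core, (4-methylphenyl in place of 3-methylphenyl on an oxygen on a saturated carbon), and in this assay compound 2 gives 251 nM, which is a 2.1-fold lower number from compound 1 to compound 2 (0.32 log units; beyond the scatter). Compound 3 `FC(F)(F)c1cccc(OC2CCN(c3ccc(-n4ccnc4)nn3)CC2)c1` gives 19 nM. The change from compound 2 to compound 3 is trifluoromethyl in place of methyl on an aromatic carbon, and it gave a 13-fold lower number from compound 2 to compound 3 (1.12 log units; beyond the scatter). Compound 4 `FC(F)(F)c1ccc(OC2CCN(c3ccc(-n4ccnc4)nn3)CC2)cc1` has not been measured; it differs from compound 1 by trifluoromethyl in place of methyl on an aromatic carbon. This is the same kind of change, but the place differs: meta to a large group in compound 3, para to a large group in compound 4. Resting on a 13-fold lower number from compound 2 to compound 3 (1.12 log units; beyond the scatter), and allowing for the different place, a somewhat smaller step is expected for compound 4, namely an 11-fold lower number from compound 1 to compound 4 (1.02 log units; beyond the scatter). Compound 4 is therefore estimated at 50 nM in this assay.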

Compound 4, half-maximal inhibitory concentration: 371 nM
Compound 4: the middle estimate sits 7.4-fold (0.87 log units) below what was measured, outside the stated range (above it).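

Putting trifluoromethyl in place of methyl para to a large group gave a 1.4-fold lower number from compound 1 to compound 4 (0.15 log units; within the scatter) in this assay, so the large gain seen on going to compound 3 did not carry over to the core of compound 1. The two steps clearly differ: the same change on two cores in this assay, a 13-fold lower number (1.12 log units; beyond the scatter) from compound 2 to compound 3 and a 1.4-fold lower number (0.15 log units; within the scatter) from compound 1 to compound 4, 9.3-fold (0.97 log units) apart, beyond the scatter of two such steps
In this series, then, a step measured on one core cannot simply be added to another, but this does not show why the two steps differ, and each rests on a single pair of compounds.

The compounds shown leave open whether other groups, such as a chlorine atom, a nitrile or a methoxy group, would also differ between the two cores. They also leave open how a ring carrying no group at all would compare.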